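A few compounds are considered here, and "the series" means these few. Any claim that something is new, unique, unknown or untested is made for them only; others in the source may bear on it.

Measured so far in an ADME assay on cells (Hepatocyte, Mus musculus) for metabolic stability, with a stated time of 30 min (on this read-out lower numbers stand for a less stable compound and higher numbers for a more stable compound), all on the shared core:
- compound 1 `CS(=O)(=O)NC1CCC(CN2CCN(c3cc(=O)c4cc(C(F)(F)F)cc([N+](=O)[O-])c4s3)CC2)CC1` gives 111%
- compound 2 `CC(=O)OC1CCC(CN2CCN(c3cc(=O)c4cc(C(F)(F)F)cc([N+](=O)[O-])c4s3)CC2)CC1` gives 0%
- compound 3 `O=C(OC1CCC(CN2CCN(c3cc(=O)c4cc(C(F)(F)F)cc([N+](=O)[O-])c4s3)CC2)CC1)c1ccco1` gives 0.6%

Compound 3 sits in the low group of these numbers, not separable from its nearest neighbour and far from the top value. The next compound to read is compound 4 `COc1ccc(C(=O)OC2CCC(CN3CCN(c4cc(=O)c5cc(C(F)(F)F)cc([N+](=O)[O-])c5s4)CC3)CC2)cc1`, and the change is 4-methoxyphenyl in place of furan-2-yl on a carbonyl carbon, in words 4-methoxyphenyl in place of furan-2-yl on a carbonyl carbon.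

The closest measured precedent is the other change on that carbonyl carbon, a number 0.6 percentage points higher from compound 2 to compound 3 (within the scatter), which is small. The two large steps, a number 111 percentage points lower from compound 1 to compound 2 (beyond the scatter) and a number 110.4 percentage points lower from compound 1 to compound 3 (beyond the scatter), both replace methanesulfonamido on a saturated ring carbon, and nothing of that kind happens here. Going by the values given here, no measured compound carries 4-methoxyphenyl, so this rests on a single precedent. The expected change is a number 1.4 percentage points higher from compound 3 to compound 4 (within the scatter), so no move beyond the scatter is expected. In this assay compound 4 is estimated at 2% in an expected range from 0% to 12% around that middle.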

Compound 4, percent of the compound remaining: 31%
For compound 4 the middle estimate is 29 percentage points below the measured one, outside the stated range (above it).
By their numbers in this assay, from the lowest: compounds 2 and 3 (each within the scatter of the next); then compound 4; then compound 1.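

In this assay the group on this carbonyl carbon turns out to matter: 4-methoxyphenyl gives a number 30.4 percentage points higher from compound 3 to compound 4 (beyond the scatter) and, set against methyl, a number 31 percentage points higher from compound 2 to compound 4 (beyond the scatter), whereas furan-2-yl in place of methyl stayed within the scatter (a number 0.6 percentage points higher from compound 2 to compound 3 (within the scatter)). The compounds with a carbonyloxy group on the saturated ring carbon therefore do not all sit at the bottom of the scale, though methanesulfonamido remains clearly ahead, with a number 80 percentage points lower from compound 1 to compound 4 (beyond the scatter). Nothing at hand bears on what lies behind these steps.

Still open, going by these compounds, is whether the rise belongs to the methoxy group or to the six-membered aromatic ring, which an unsubstituted phenyl or a 4-chlorophenyl on the same carbonyl carbon would help to separate. Also open, on these data alone, is where a carboxamide in place of ((4-methoxyphenyl)carbonyl)oxy on the saturated ring carbon would stand.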